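Swapping the aryl group on compound 1's imine nitrogen

The source may hold more compounds than are shown below. What is called first, only, known or untested is meant among the compounds shown, and "the series" means these compounds.

Compound 1 `Cc1cccc(/N=C2/NC(=O)/C(=C/c3ccccn3)S2)c1` was tested in a functional assay on the whole organism (strain Wistar) for inhibition, with Rattus norvegicus as the target, read by paw edema, with stated times of 30 min and 120 min, at a dose of 10 mg/kg by the oral route (on this read-out higher numbers stand for more inhibition at the one dose given (going by the name of the read-out) and lower numbers for less inhibition), and gave 39.7%. Compound 2 `O=C1N/C(=N\Nc2ccccc2)S/C1=C\c1ccccn1` gave 39.7% in this assay, the same number at the digits shown as compound 1, and compound 3 `O=C1N/C(=N/c2cccc([N+](=O)[O-])c2)S/C1=C\c1ccccn1` gave 43.5%. Within the data shown here, the one change that can be followed directly is a number 3.8 percentage points higher from compound 1 to compound 3 (within the scatter), which stays within the scatter, so the three measured numbers sit close together with no separation that can be trusted.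

Compound 4 `O=C1N/C(=N/c2ccccc2Cl)S/C1=C\c1ccccn1` differs from compound 1 in one place: 2-chlorophenyl in place of 3-methylphenyl on a double-bonded nitrogen. Among the measured compounds shown here, no measured step swaps one aryl group for another at this position, so the only guide is that the change from compound 1 to compound 3 on the same aryl ring, a number 3.8 percentage points higher from compound 1 to compound 3 (within the scatter), did not move the read-out beyond the scatter. The expected step is therefore a number 1.3 percentage points higher from compound 1 to compound 4 (within the scatter), that is, none beyond the scatter. Compound 4 is estimated at 41% in this assay, within a range from 30% to 52%.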

Compound 4, a percentage reported as inhibition, in the whole organism at one dose (the size of the read-out at that dose, not a potency): 26.2%
The estimate for compound 4 lay 14.8 percentage points above the measured number; measured number outside the range, below it.
By their numbers in this assay, from the lowest: compound 4; then compounds 1, 2 and 3 (each within the scatter of the next).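

Among these compounds, replacing 3-methylphenyl with 2-chlorophenyl on a double-bonded nitrogen gives the first step in this assay that goes beyond the scatter, with a number 13.5 percentage points lower from compound 1 to compound 4 (beyond the scatter), so the read-out does respond to which aryl group sits at this position. The two groups have the same counts of heavy atoms, hydrogen-bond donors and hydrogen-bond acceptors, and each has one six-membered aromatic ring of carbon only, so none of these counts separates them. No measurement shown here explains the drop.

This swap changes both the substituent and its numbered place on the ring, so the compounds shown cannot tell which of the two matters; 3-chlorophenyl and 2-methylphenyl would separate them. On these data alone, how an aryl ring carrying an amine or a carboxylic acid would behave here also remains open.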